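Replacing the Fluorophenyl Group in a Cytotoxicity Series

This account rests on a few compounds, and the source may have more. Where it says the series, first, only, none or still open, it means among the compounds named here.

Compound 1 `COc1cc2c(Oc3ccc(NC(=O)c4cc(-c5ccc(F)cc5)ccn4)cc3F)ccnc2cc1OCCCN1CCN(C)CC1` — 510 nM
Compound 2 `COc1cc2c(Oc3ccc(NC(=O)c4cc(-c5ccc(F)cc5)ccn4)cc3F)ccnc2cc1OCCCN1CCCC1` — 350 nM

In a functional assay on MKN-45 cells (Homo sapiens) for cytotoxicity, read by MTT assay, with a stated time of 72 h (a higher number here means a weaker inhibitor, a lower number a stronger inhibitor), compound 2 gives the lowest of these two numbers, but the step of a 1.5-fold lower number from compound 1 to compound 2 (0.16 log units; within the scatter) lies within the scatter, so compound 1 and compound 2 cannot be told apart. Compound 3 `COc1ccc(-c2ccnc(C(=O)Nc3ccc(Oc4ccnc5cc(OCCCN6CCCC6)c(OC)cc45)c(F)c3)c2)c(OC)c1` differs from compound 2 by 2,4-dimethoxyphenyl in place of 4-fluorophenyl on an aromatic carbon. For the measured compounds named here, the single measured step concerns a different part of the shared core and was itself within the scatter, so it gives no guidance for this change. The step of a 1.1-fold higher number from compound 2 to compound 3 (0.06 log units; within the scatter) is therefore expected to be small in either direction, with a wide range. Compound 3 is estimated at 400 nM, between 120 nM and 1500 nM.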

Compound 3, half-maximal inhibitory concentration: 740 nM
Beside the measured number, compound 3's estimate is 1.9-fold (0.27 log units) below it, and the stated range covers the measured number.
By their numbers in this assay, from the lowest: compounds 2, 1 and 3 (each within the scatter of the next, the first and the last beyond it).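

At the aromatic carbon opposite the ring nitrogen, the swap of 4-fluorophenyl for 2,4-dimethoxyphenyl gives a 2.1-fold higher number from compound 2 to compound 3 (0.33 log units; beyond the scatter) in this assay, a modest change. This is the only step shown that lies beyond the scatter, as the earlier change on the saturated chain did not. Nothing available explains this shift.

Going by these compounds, whether both methoxy groups are needed for this step remains open. A 4-methoxyphenyl or a plain phenyl group at the same position could separate their contributions.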